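Removing the Methyl Group Beside the Ring Nitrogen

This account rests on a few compounds, and the source may have more. Where it says the series, first, only, none or still open, it means among the compounds named here.

compound 1 `Clc1cncc(N2CCCNCCC2)c1` gives 2 nM
compound 2 `Oc1cc(N2CCCNCC2)cnc1I` gives 21.9 nM
compound 3 `Cc1ncc(N2CCNCC2)cc1Cl` gives 525 nM

Of the compounds shown here, three have been measured in an assay on HEK293 cells for displacement of a labelled ligand from Neuronal acetylcholine receptor; alpha4/beta2 (Homo sapiens); on this read-out higher numbers stand for weaker inhibition and lower numbers for stronger inhibition. Compound 3 stands at the highest of the three numbers: compound 2 sits below it by a margin beyond the scatter, and compound 1 sits further below by a margin also beyond the scatter. Compound 4 `Clc1cncc(N2CCNCC2)c1` is the unmeasured neighbour of compound 3. The change is hydrogen in place of methyl on an aromatic carbon; it sits on the aromatic carbon next to the ring nitrogen, ortho to the chloro group.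

Within the data shown here, no step between measured compounds is available for this change, so the expectation rests on compound 3 alone, whose value is 525 nM, and on the general level of the other two. Compound 4 is expected to move downward from compound 3 by a step beyond the scatter, a 26-fold lower number from compound 3 to compound 4 (1.42 log units; beyond the scatter), as an estimate. The expected value for compound 4 in this assay is 20 nM, within a range from 4 nM to 100 nM.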

Compound 4, half-maximal inhibitory concentration: 309 nM
Compound 4: the middle estimate sits 15-fold (1.19 log units) below what was measured, and the stated range ends below it.
By their numbers in this assay, from the lowest: compound 1; then compound 2; then compounds 4 and 3 (each within the scatter of the next).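

In this assay, hydrogen in place of methyl on this aromatic carbon gives a 1.7-fold lower number from compound 3 to compound 4 (0.23 log units; within the scatter), so the two compounds cannot be told apart on this read-out. Among these compounds, this is the first direct reading at this position: with the chloro group and the rest of the shared core held fixed, the methyl group can be present or absent without a difference that stands clear of the scatter. Nothing at hand gives a reason for this result.

The compounds shown leave open whether other groups on this aromatic carbon, such as a methoxy group, an amine or a longer chain, would read like methyl and hydrogen do here. They also leave open whether the same exchange would read the same way on the core of compound 1.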